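From Furan-2-yl to Phenyl: An Expected Modest Step

The compounds below may be only part of what the source reports. "The series", "measured", "known", "first", "only" and "open" are said of these compounds alone.

Three compounds share a core carrying a 4-hydroxyphenyl group and a 3-chlorophenyl group, and differ in one aromatic substituent. Compound 1 `Oc1ccc(-c2cc(-c3cccc(Cl)c3)nc(-c3ccccn3)c2)cc1` gives 59.4% in an assay on isolated protein for inhibition of DNA topoisomerase 1 (Homo sapiens), with a stated time of 30 min, tested at 100 uM; on this read-out lower numbers stand for a weaker effect and higher numbers for a stronger effect at the one concentration tested. Compound 2 `Oc1ccc(-c2cc(-c3ccsc3)nc(-c3cccc(Cl)c3)c2)cc1` gives 26%, and compound 3 `Oc1ccc(-c2cc(-c3cccc(Cl)c3)nc(-c3ccco3)c2)cc1` gives 25.5%, the lowest of the three numbers, though its gap to compound 2 lies within the scatter, as a number 0.5 percentage points lower from compound 2 to compound 3 (within the scatter) shows.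

Compound 4 `Oc1ccc(-c2cc(-c3ccccc3)nc(-c3cccc(Cl)c3)c2)cc1` is not yet measured. It differs from compound 3 by phenyl in place of furan-2-yl on an aromatic carbon.

Among the compounds with values here, no measured step involves phenyl, so the expectation rests on what is seen: both large drops, a number 33.4 percentage points lower from compound 1 to compound 2 (beyond the scatter) and a number 33.9 percentage points lower from compound 1 to compound 3 (beyond the scatter), came when pyridin-2-yl left, and the exchange between two five-membered rings, a number 0.5 percentage points lower from compound 2 to compound 3 (within the scatter), changed little. Compound 4 keeps the same 3-chlorophenyl group next to the ring nitrogen that compound 2 carries there. A step within or only slightly beyond the scatter, a number 4.5 percentage points higher from compound 3 to compound 4 (within the scatter), is therefore expected. For compound 4 the estimate is 30%, with a range from 12% to 52%.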

Compound 4, a percentage reported as inhibition, at one concentration (the size of the read-out at that concentration, not a potency): 0%
For compound 4 the middle estimate is 30 percentage points above the measured one; measured number below the stated range.
By their numbers in this assay, from the lowest: compound 4; then compounds 3 and 2 (each within the scatter of the next); then compound 1.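

Phenyl turns out to be the poorest of the four groups at this position next to the ring nitrogen, which the two five-membered rings alone could not show. In this assay, the change from furan-2-yl gives a number 25.5 percentage points lower from compound 3 to compound 4 (beyond the scatter) and the change from thiophen-3-yl gives a number 26 percentage points lower from compound 2 to compound 4 (beyond the scatter), while a number 59.4 percentage points lower from compound 1 to compound 4 (beyond the scatter) shows that a six-membered aromatic ring is not enough, since pyridin-2-yl and phenyl differ in the ring nitrogen. All three rings holding a hetero atom read above this ring of carbon only, though no measurement here explains that difference.

From the compounds shown here alone, whether a phenyl ring carrying an amine or a carboxylic acid, or a pyridin-4-yl group, would bring the read-out back remains open. Also open, going by these compounds, is whether this order would hold at other concentrations, as only one is reported.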